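The source may report more compounds than this note shows. Statements on the series, on what has been measured and on what is new or still open speak of the compounds shown alone.

Measured compounds:
compound 1, `CC(C)CNC(=O)n1c(=O)oc2cc(C3CCCN(C)C3)ccc21`, with > 250000 nM in a physicochemical assay for solubility, read by HPLC, in phosphate buffer, measured as kinetic solubility, with a stated time of 1 h, at pH 7.4, tested at 250 uM; a higher number here means a more soluble compound, a lower number a less soluble compound;
compound 2, `CCN1CCN(c2ccc3c(c2)oc(=O)n3C(=O)NCCCCc2ccccc2)CC1`, with < 1000 nM.

Compound 1 sits at a limit of this assay, so its value is a limit and not a number; this is the limit of > 250000 nM in this assay, at which 1 of the 2 values shown sits. Compound 2 likewise sits at a limit, the one given by the limit of < 1000 nM in this assay, at which 1 of the 2 values shown sits, so for compound 2 only a limit is known and no number. Among the compounds with values here, the two values therefore show only that compound 1 and compound 2 sit at opposite ends of the window of this assay, and no step between them can be stated.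

Compound 3, `CN1CCC(c2ccc3c(c2)oc(=O)n3C(=O)NCCCCc2ccccc2)CC1`, has not yet been measured. It differs from compound 2 by 1-methylpiperidin-4-yl in place of 4-ethylpiperazin-1-yl on an aromatic carbon. Within the data shown here, no step between measured compounds bears on this change, so the expected size rests on compound 2 alone, whose value is a limit.

Compound 3 is expected to give 2000 nM, within 500 nM to 20000 nM. The expected step of an at least 2.0-fold higher number from compound 2 to compound 3 (0.30 log units; that floor lies within the scatter) is small, in the direction of higher solubility, and may well not exceed the scatter.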

Compound 3, solubility: 120000 nM
The estimate for compound 3 lay 60-fold (1.78 log units) below the measured number; measured number above the stated range.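

At the aromatic carbon that is meta to a fused ring and para to a fused ring, 1-methylpiperidin-4-yl in place of 4-ethylpiperazin-1-yl proves to be a large change in this assay, with an at least 120-fold higher number from compound 2 to compound 3 (2.07 log units; beyond the scatter). The size of this step has only a floor, since compound 2 is known only as a limit: the limit of < 1000 nM in this assay, at which 1 of the 3 values shown sits. Compound 3 is the only one of the three compounds shown with a number rather than a limit in this assay, so it gives later changes on this core a value that can be read in either direction.

The exchange alters more than one feature at once, replacing a ring with two nitrogens by a ring with one and an ethyl group on nitrogen by a methyl group, so the compounds shown do not say which of these differences carries the step. From the compounds shown here alone, a 4-methylpiperazin-1-yl or a 1-ethylpiperidin-4-yl group at this place would separate the two, and whether the high number in this assay also holds for a morpholine ring there remains open.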